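Trading an acetamido group for a fluorinated carbonyloxy group

This account rests on a few compounds, and the source may have more. Where it says the series, first, only, none or still open, it means among the compounds named here.

Of the compounds shown here, three sharing one core have been measured so far in an ADME assay on cells (Hepatocyte, Homo sapiens) for metabolic stability, with a stated time of 30 min; a higher number here means that more of the compound is left, a lower number that less of the compound is left. Compound 3 `CC(=O)NC1CCC(CN2CCN(c3cc(=O)c4cc(C(F)(F)F)cc([N+](=O)[O-])c4s3)CC2)CC1` stands highest of the three at 86.8%, clearly separated from the other two. Compound 1 `O=C(OC1CCC(CN2CCN(c3cc(=O)c4cc(C(F)(F)F)cc([N+](=O)[O-])c4s3)CC2)CC1)c1ccncc1` gives 1% and compound 2 `O=C(OC1CCC(CN2CCN(c3cc(=O)c4cc(C(F)(F)F)cc([N+](=O)[O-])c4s3)CC2)CC1)C1CCCCC1` gives 2.8%, two numbers that cannot be told apart within the usual scatter.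

The next structure, compound 4 `O=C(OC1CCC(CN2CCN(c3cc(=O)c4cc(C(F)(F)F)cc([N+](=O)[O-])c4s3)CC2)CC1)c1ccc(F)cc1`, has not yet been measured. It carries ((4-fluorophenyl)carbonyl)oxy in place of acetamido on a saturated ring carbon.

Within the data shown here, two measured steps bear most directly on this change, once they are read in reverse. The first is a number 85.8 percentage points higher from compound 1 to compound 3 (beyond the scatter), and the second is a number 84 percentage points higher from compound 2 to compound 3 (beyond the scatter). Both are large and beyond the scatter, and both put acetamido in place of a carbonyloxy group. A third step, a number 1.8 percentage points higher from compound 1 to compound 2 (within the scatter), stays within the scatter, although it replaces pyridin-4-yl with cyclohexyl on a carbonyl carbon. Among the measured compounds shown here, no measured compound carries the 4-fluorophenyl version, so this comparison is indirect. A large drop in this assay is therefore expected, similar in size to those two steps.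

The estimated change is a number 84.3 percentage points lower from compound 3 to compound 4 (beyond the scatter).

For compound 4 the expected value is 2.5%, with an estimated range from 0.5% to 12%.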

Compound 4, percent of the compound remaining: 3%
Beside the measured number, compound 4's estimate is 0.5 percentage points below it, within the range that was stated.
By their numbers in this assay, from the lowest: compounds 1, 2 and 4 (each within the scatter of the next); then compound 3.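

Compound 4 is the third compound with a carbonyloxy group on this saturated ring carbon, and with an aromatic ring carrying fluorine it again falls far short of the acetamido compound in this assay: a number 83.8 percentage points lower from compound 3 to compound 4 (beyond the scatter). Among the carbonyloxy compounds, the group on the carbonyl carbon has so far made no visible difference, with a number 0.2 percentage points higher from compound 2 to compound 4 (within the scatter) and a number 2 percentage points higher from compound 1 to compound 4 (within the scatter), so 4-fluorophenyl, cyclohexyl and pyridin-4-yl cannot be told apart here. No measurement offered here explains the large gap between the acetamido compound and these three.

Compound 3 differs from the other three both in the atom that links the carbonyl to the ring and in the group on the carbonyl carbon, so the compounds shown cannot say which of these two differences matters. A small acetyloxy group would keep the oxygen link with the methyl of compound 3, while a 4-fluorobenzamido group would keep the nitrogen link with the aromatic ring of compound 4, and these two would pull the differences apart.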